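The compounds below may be only part of what the source reports. "The series", "measured", "known", "first", "only" and "open" are said of these compounds alone.

Two compounds have been measured in a functional assay on NCI-H226 cells (Homo sapiens) for inhibition, read by sulforhodamine B assay, with a stated time of 48 h; on this read-out lower numbers stand for stronger inhibition of growth and higher numbers for weaker inhibition of growth:
compound 1, `NS(=O)(=O)c1ccc(Nc2nc(N/N=C/c3ccc(C(F)(F)F)cc3)nc(Nc3ccccc3)n2)cc1`, gives 2450 nM
compound 2, `Cc1nn(-c2ccccc2)cc1/C=N/Nc1nc(Nc2ccccc2)nc(Nc2ccc(S(N)(=O)=O)cc2)n1`, gives 1850 nM

Among these two numbers compound 2 holds the lower one, but its only neighbour, compound 1, sits apart by just a 1.3-fold lower number from compound 1 to compound 2 (0.12 log units; within the scatter), a gap within the scatter, so the two compounds cannot be told apart on this read-out. Compound 3, `NS(=O)(=O)c1ccc(Nc2nc(N/N=C/c3ccccn3)nc(Nc3ccccc3)n2)cc1`, differs from compound 2 by pyridin-2-yl in place of 3-methyl-1-phenyl-1H-pyrazol-4-yl on a carbon with a double bond to nitrogen. Going by the values given here, the one measured step that bears on it, a 1.3-fold lower number from compound 1 to compound 2 (0.12 log units; within the scatter), concerns the same place with a different group and stayed within the scatter. Nothing measured speaks to a pyridin-2-yl at this place, so no move beyond the scatter is expected in this assay. Compound 3 is therefore estimated at 2400 nM, with a range from 800 nM to 7500 nM. That estimate means an expected step of a 1.3-fold higher number from compound 2 to compound 3 (0.11 log units; within the scatter), inside the scatter.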

Compound 3, concentration for 50% growth inhibition: 1070 nM
The estimate for compound 3 lay 2.2-fold (0.35 log units) above the measured number; the range from low to high includes it.
By their numbers in this assay, from the lowest: compounds 3, 2 and 1 (each within the scatter of the next, the first and the last beyond it).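

In this assay, the place on a carbon with a double bond to nitrogen now gives its first step beyond the scatter: pyridin-2-yl in place of 4-(trifluoromethyl)phenyl brings a 2.3-fold lower number from compound 1 to compound 3 (0.36 log units; beyond the scatter), a modest change. The exchange of 3-methyl-1-phenyl-1H-pyrazol-4-yl for the smaller pyridin-2-yl gives a 1.7-fold lower number from compound 2 to compound 3 (0.24 log units; within the scatter), so these two groups cannot be told apart on this read-out. No available evidence accounts for either step.

The compounds shown leave open whether the ring nitrogen of pyridin-2-yl matters at this place, which a plain phenyl or a pyridin-4-yl would test. They also leave open how a pyridin-2-yl carrying an amine or a carboxylic acid would read.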